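Lipophilicity notes on a triazolyl-indole series

The source may report more compounds than this note shows. Statements on the series, on what has been measured and on what is new or still open speak of the compounds shown alone.

Measured compounds:
compound 1 `CC(C)Sc1nnc(-c2c(CNC3CC3)c3ccccc3n2C)n1-c1ccccc1` — 4.81
compound 2 `CC1CCCN(Cc2c(-c3nnc(SC(C)C)n3-c3ccccc3)n(C)c3ccccc23)C1` — 6.03
compound 3 `CC(C)Sc1nnc(-c2c(CNC3CC3)c3cc(F)ccc3n2C)n1-c1ccccc1` — 4.97

The three compounds have been measured in a physicochemical assay for lipophilicity (on this read-out lower numbers stand for lower lipophilicity and higher numbers for higher lipophilicity), and share a common framework; they differ at two places only.

The first place is the saturated chain carbon bound to an aromatic carbon. From compound 1 to compound 2 the change there is 3-methylpiperidin-1-yl in place of cyclopropylamino on a saturated chain carbon bound to an aromatic carbon. That single exchange moves the read-out a number 1.22 log units higher from compound 1 to compound 2 (beyond the scatter) — clearly the dominant effect seen so far.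

The second place is an aromatic carbon of the fused ring system. From compound 1 to compound 3 the change is fluoro in place of hydrogen on an aromatic carbon. Here the read-out moves only a number 0.16 log units higher from compound 1 to compound 3 (within the scatter), so compound 1 and compound 3 cannot be told apart on this measure.

Compound 4 `CC1CCCN(Cc2c(-c3nnc(SC(C)C)n3-c3ccccc3)n(C)c3ccc(F)cc23)C1` is not yet measured in this assay. It relates to compound 3 exactly as compound 2 relates to compound 1: the change is 3-methylpiperidin-1-yl in place of cyclopropylamino on a saturated chain carbon bound to an aromatic carbon, made at the same place in the same words, so it is the same change, made on the core that carries fluorine rather than hydrogen. The two cores differ by fluoro in place of hydrogen on an aromatic carbon, which in this assay gave no step beyond the scatter. The expectation for compound 4 therefore rests on one matched pair: the step from compound 3 to compound 4 is estimated at a number 1.22 log units higher from compound 3 to compound 4 (beyond the scatter), alongside the earlier a number 1.22 log units higher from compound 1 to compound 2 (beyond the scatter), because the core exchange alone gave only a number 0.16 log units higher from compound 1 to compound 3 (within the scatter). On that basis compound 4 is expected to read 6.19, with a plausible range from 5.75 to 6.65.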

Compound 4, partition coefficient: 6.18
Compound 4: the middle estimate sits 0.01 log units above what was measured, within the range that was stated.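

In this assay, 3-methylpiperidin-1-yl in place of cyclopropylamino on a saturated chain carbon bound to an aromatic carbon carries over to the fluorine-bearing core, with the number a number 1.21 log units higher from compound 3 to compound 4 (beyond the scatter), close to the earlier step, which put it a number 1.22 log units higher from compound 1 to compound 2 (beyond the scatter), while fluoro in place of hydrogen on the piperidine-bearing core stays small at a number 0.15 log units higher from compound 2 to compound 4 (within the scatter). This is a single transfer between two cores that differ only by that fluoro exchange, so it shows the two changes behaving independently for these four compounds and says nothing about cores that differ more widely or about any other pair of groups. Nothing at hand bears on what lies behind the size of the step.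

The exchange alters the ring, the heavy-atom count and the hydrogen-bond donor count together, so these four compounds leave open how much of the step belongs to each, and an unsubstituted piperidine or a morpholine on the same chain carbon would speak to that. Also open, going by these compounds, is whether the step holds on a core with chloro or methoxy in place of the fluoro group.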